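The source may hold more compounds than are shown below. What is called first, only, known or untested is meant among the compounds shown, and "the series" means these compounds.

Compound 1, `COc1cc(/C=C/C(=O)OCCc2ccccc2F)cc(OC)c1O`, is the reference point of this comparison. In an assay on PMNL cells for inhibition of Polyunsaturated fatty acid 5-lipoxygenase (Homo sapiens), read by HPLC, with stated times of 5 min and 15 min (on this read-out lower numbers stand for stronger inhibition and higher numbers for weaker inhibition), compound 1 gives 240 nM, the lowest of the two numbers recorded so far. For the measured compounds named here, its only measured neighbour is compound 2, `COc1cc(/C=C/C(=O)OCCc2ccccc2C(F)(F)F)cc(OC)c1O`, which in this assay gives 350 nM; the step from compound 1 to compound 2 is a 1.5-fold higher number from compound 1 to compound 2 (0.16 log units; within the scatter), a change that does not rise above the scatter of the measurement.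

Compound 3, `COc1cc(/C=C/C(=O)OCCc2ccccc2C)cc(OC)c1O`, has not yet been measured. It differs from compound 1 in a single place: methyl in place of fluoro on an aromatic carbon. Going by the values given here, the one measured step that bears on this change is the one at the same aromatic carbon, where fluoro gave way to trifluoromethyl, and that step stayed within the scatter. With only this to go on, the exchange of fluoro for methyl at the same position is expected to leave the number in this assay essentially where compound 1 stands, so the step from compound 1 to compound 3 is expected to be a 1.2-fold higher number from compound 1 to compound 3 (0.07 log units; within the scatter). Compound 3 is therefore estimated at 280 nM in this assay, with a range from 120 nM to 650 nM.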

Compound 3, half-maximal inhibitory concentration: 240 nM
Compound 3: the middle estimate sits 1.2-fold (0.07 log units) above what was measured; the range from low to high includes it.
By their numbers in this assay, from the lowest: compounds 1, 3 and 2 (each within the scatter of the next).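

In this assay, putting methyl in place of fluoro on this aromatic carbon, ortho to a large group, gives no change at the digits printed from compound 1 to compound 3 (within the scatter). Methyl in place of trifluoromethyl at the same carbon gives a 1.5-fold lower number from compound 2 to compound 3 (0.16 log units; within the scatter). The earlier compounds shown here offered a single exchange at this position, whereas the three groups now link up in steps that all stay within the scatter, so this read-out does not separate fluoro, methyl and trifluoromethyl here. Nothing available explains why these three groups read alike at this position.

The compounds shown leave open whether this evenness extends to groups of another kind at this aromatic carbon, such as an amine, a carboxylic acid or a longer chain like butyl. They also leave open whether fluoro, methyl and trifluoromethyl would read alike at another carbon of the same ring, or whether this evenness holds only for the place examined here.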